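Adding a methyl to compound 3 at the assay limit

The source may hold more compounds than are shown below. What is called first, only, known or untested is meant among the compounds shown, and "the series" means these compounds.

Compound 3 (`C/C=C1/[C@H](O[C@@H]2O[C@H](COC(C)=O)[C@@H](OC(C)=O)[C@H](OC(C)=O)[C@H]2OC(C)=O)OC=C(C(=O)O)[C@H]1CC(=O)O`) gives only a limit of > 20000 nM in a functional assay on SK-BR-3 cells (Homo sapiens) for antiproliferative activity, read by MTT assay, with a stated time of 72 h (on this read-out lower numbers stand for stronger inhibition and higher numbers for weaker inhibition), and no number. Compound 1 (`C/C=C1/[C@H](O[C@@H]2O[C@H](COC(C)=O)[C@@H](OC(C)=O)[C@H](OC(C)=O)[C@H]2OC(C)=O)OC=C(C(=O)OC)[C@H]1CC(=O)O`) also reads only as the limit > 15000 nM there. Compound 2 (`C/C=C1/[C@H](O[C@@H]2O[C@H](COC(C)=O)[C@@H](OC(C)=O)[C@H](OC(C)=O)[C@H]2OC(C)=O)OC=C(C(=O)OC)[C@H]1CC(=O)SCCC`) likewise reads only as the limit > 15000 nM there. The change to compound 4 (`C/C=C1/[C@H](O[C@@H]2O[C@H](COC(C)=O)[C@@H](OC(C)=O)[C@H](OC(C)=O)[C@H]2OC(C)=O)OC=C(C(=O)O)[C@H]1CC(=O)OC`) is methyl in place of hydrogen on an oxygen next to a carbonyl group and reads carboxymethyl to (methoxycarbonyl)methyl. Among the compounds with values here, two measured steps bear on it: a step that the two limits leave unreadable from compound 1 to compound 3 for the reverse kind of swap on another carboxy group, and a step that the two limits leave unreadable from compound 1 to compound 2 for propylsulfanyl in place of hydroxy. Neither has a readable size, so no step beyond the scatter is expected in this assay and no direction is foreseen. The estimated step is a number no higher from compound 3 to compound 4 (the limit leaves the size open) in size. For compound 4 the estimated value is 20000 nM within a range from 8000 nM to 50000 nM and a limit is the likeliest report.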

Compound 4, half-maximal inhibitory concentration: > 20000 nM
Compound 4: only a limit was reported; the forecaster's own chance of this, stated with the estimate: 85%; the middle value lies on the limit itself.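

Compound 4, like compound 3, reads only as a limit in this assay, so no size can be read for the step between them. Going by these compounds, with compounds 1 to 4 all at limits, what any of these single changes does stays open.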